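A methyl in place of bromo at compound 3

The compounds below may be only part of what the source reports. "The series", "measured", "known", "first", "only" and "open" are said of these compounds alone.

Compound 1 `S=C(N/N=C\c1ccnc2ccccc12)Nc1ccccc1`: 1070 nM
Compound 2 `S=C(N/N=C\c1ccnc2ccccc12)Nc1ccc(Cl)cc1`: 1070 nM
Compound 3 `S=C(N/N=C\c1ccnc2ccccc12)Nc1ccc(Br)cc1`: 990 nM

These values come from a functional assay on MCF7 cells (Homo sapiens) for cytotoxicity, read by MTT assay, with a stated time of 48 h (on this read-out higher numbers stand for weaker inhibition and lower numbers for stronger inhibition), where compound 3 stands level with compound 1 and compound 2, all three lying within the scatter of each other. Compound 4 `Cc1ccc(NC(=S)N/N=C\c2ccnc3ccccc23)cc1` carries methyl in place of bromo on an aromatic carbon, para to a large group (methyl in place of bromo on an aromatic carbon). Within the data shown here, the steps that bear on this change are no change at the digits printed from compound 1 to compound 2 (within the scatter), a 1.1-fold lower number from compound 1 to compound 3 (0.03 log units; within the scatter) and a 1.1-fold lower number from compound 2 to compound 3 (0.03 log units; within the scatter). Among the measured compounds shown here, none of them leaves the scatter, though no methyl compound has been measured. The expected step is therefore a 1.1-fold higher number from compound 3 to compound 4 (0.03 log units; within the scatter), with none expected beyond the scatter. The estimate for compound 4 is 1050 nM, with an expected range of 600 nM to 1800 nM.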

Compound 4, half-maximal inhibitory concentration: 980 nM
Beside the measured number, compound 4's estimate is 1.1-fold (0.03 log units) above it, within the range that was stated.
By their numbers in this assay, from the lowest: compounds 4, 3, 1 and 2 (each within the scatter of the next).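

In this assay methyl at this place, para to a large group, behaves as the halogens and hydrogen do: against bromo the step is (a 1.0-fold lower number from compound 3 to compound 4 (0.00 log units; within the scatter)), against chloro (a 1.1-fold lower number from compound 2 to compound 4 (0.04 log units; within the scatter)) and against hydrogen (a 1.1-fold lower number from compound 1 to compound 4 (0.04 log units; within the scatter)). The flat picture at this position therefore now extends beyond halogens to a carbon group, and all four compounds lie within the scatter of each other. No supporting measurement accounts for this result.

On these data alone, whether an amine, a carboxylic acid or a longer chain at this place would also stay within the scatter remains open. So does the effect of methyl or bromo elsewhere on the six-membered aromatic ring.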